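The source may hold more compounds than are shown below. What is called first, only, known or untested is meant among the compounds shown, and "the series" means these compounds.

Compound 1 `CC(C)N(Cc1cccc(OCCCCCC(=O)O)c1)C(=O)c1ccccc1`: in an ADME assay on BJ cells (Homo sapiens) for cytotoxicity, read by CellTiter-Glo and resazurin assay, with a stated time of 72 h (a lower number here means that less compound is needed, a higher number that more compound is needed for the effect), compound 1 gives > 26000 nM, a limit.
Compound 2 `CCOc1cccc(-c2ccc(C(=O)N(Cc3cccc(OCCCCCC(=O)O)c3)C(C)C)cc2)c1`: in this assay compound 2 gives > 20800 nM, a limit.
Compound 3 `COc1cc(OC)cc(-c2ccc(C(=O)N(Cc3cccc(OCCCCCC(=O)O)c3)C(C)C)cc2)c1`: in this assay compound 3 gives > 26000 nM, a limit.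

Compound 3 thus stands at a limit, and the other two values shown are limits as well; two of the three sit at the limit of > 26000 nM in this assay, at which 2 of the 3 values shown sit, and one at the limit of > 20800 nM in this assay, at which 1 of the 3 values shown sits. The steps a step that the two limits leave unreadable from compound 1 to compound 2, a step that the two limits leave unreadable from compound 1 to compound 3 and a step that the two limits leave unreadable from compound 2 to compound 3 are therefore all unreadable in size. Compound 4 `CC(C)N(Cc1cccc(OCCCCCC(=O)O)c1)C(=O)c1ccc(-c2cccc(OC(F)(F)F)c2)cc1` differs from compound 3 by 3-(trifluoromethoxy)phenyl in place of 3,5-dimethoxyphenyl on an aromatic carbon. The earlier aryl exchanges among compounds 1, 2 and 3 never moved any value off a limit, so no step beyond the scatter is expected for a step that the limit leaves unreadable from compound 3 to compound 4. Compound 4 is estimated to give 30000 nM, between 15000 nM and 60000 nM, most likely again as a limit.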

Compound 4, half-maximal effective concentration: > 26000 nM
Compound 4: only a limit was reported (the forecaster's own chance of this, stated with the estimate: 85%); the middle value does not contradict the limit.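

In this assay, for the compounds shown here, compound 4 gives > 26000 nM, a limit, and compounds 1, 2 and 3 also stand at limits, so no step from compound 4 to any of them can be read. The compounds shown leave open where the actual values of all four lie and whether any of these aryl exchanges changes them.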